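Working notes: hemolysis across four related compounds

A few compounds are considered here, and "the series" means these few. Any claim that something is new, unique, unknown or untested is made for them only; others in the source may bear on it.

Measured so far in an ADME assay on cells (Erythrocyte, Homo sapiens) for activation, read by hemolysis, with a stated time of 30 min, tested at 5 mM; on this read-out higher numbers stand for a stronger effect at the one concentration tested and lower numbers for a weaker effect:
compound 1 `N=C(N)c1ccc(-c2ccc(-c3ccccc3)s2)s1`: 56.7%
compound 2 `COc1ccc(-c2ccc(-c3ccc(C(=N)N)o3)o2)cc1`: 36.3%
compound 3 `COc1cccc(-c2ccc(-c3ccc(C(=N)N)s3)s2)c1`: 39%

Compound 2 gives the lowest of the three numbers in this assay. Its nearest neighbour is compound 3, and the two lie within the scatter of each other, so no order is read between them. Compound 1 stands furthest from compound 2, and that gap lies beyond the scatter.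

Among the measured compounds shown here, the one counted step among the measured compounds runs from compound 3 to compound 1. The change is hydrogen in place of methoxy on an aromatic carbon and it gave a number 17.7 percentage points higher from compound 3 to compound 1 (beyond the scatter).

Compound 4 `N=C(N)c1ccc(-c2ccc(-c3ccccc3)o2)o1` has not been measured in this assay. It differs from compound 2 by hydrogen in place of methoxy on an aromatic carbon. For the measured compounds named here, this is the same kind of change as the one from compound 3 to compound 1, but not the same: in compound 3 the methoxy sits meta to a large group, in compound 2 it sits para to a large group. The cores of compound 2 and compound 3 differ in more than one place; that difference is not broken down here.

Compound 4 is expected to give 52% in this assay. Going by the values given here, the expected step is a number 15.7 percentage points higher from compound 2 to compound 4 (beyond the scatter), which rests on the one measured step of this kind, a number 17.7 percentage points higher from compound 3 to compound 1 (beyond the scatter), read beside the value of compound 2. Among the compounds with values here, with only one such step known, and at a different place on the ring, compound 4 is estimated to fall from 38% to 66%.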

Compound 4, a percentage reported as activity, at one concentration (the size of the read-out at that concentration, not a potency): 30.1%
Estimate against measurement, compound 4: 21.9 percentage points above, and the stated range ends above it.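

In this assay, taking hydrogen in place of methoxy on the para-placed carbon of compound 2 gives a number 6.2 percentage points lower from compound 2 to compound 4 (within the scatter), so compound 2 and compound 4 cannot be told apart on this read-out. The exchange therefore does not carry over as a fixed increment from one core to the other: the same change on two cores in this assay, a number 17.7 percentage points higher (beyond the scatter) from compound 3 to compound 1 and a number 6.2 percentage points lower (within the scatter) from compound 2 to compound 4, 23.9 percentage points apart, beyond the scatter of two such steps This shows that the step measured on one core is a poor guide to the step on the other, but it does not show why, since the two pairs differ both in the core and in where the methoxy sits on the six-membered aromatic ring, and two pairs cannot separate these.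

The compounds shown leave open what the same exchange gives when the methoxy stands at the same place on both cores, which would separate the effect of the core from that of the position. Also open, on these data alone, is whether an ethoxy group, a hydroxyl group or a carboxylic acid at that place on the six-membered aromatic ring would depend on the core in the same way.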